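This account rests on a few compounds, and the source may have more. Where it says the series, first, only, none or still open, it means among the compounds named here.

Working notes on a small series of chlorinated anilines bearing an oxime-type side chain.

Compound 1 is `CCO/N=C/Nc1cc(Cl)c(O)c(Cl)c1`. In a physicochemical assay for lipophilicity, measured as octanol-water partition (a higher number here means a more lipophilic compound, a lower number a more polar compound), compound 1 gives 2.8. Compound 2 is `CCO/N=C/Nc1cc(Cl)c(OC)c(Cl)c1`, differing from compound 1 by methyl in place of hydrogen on an oxygen on an aromatic ring; in this assay compound 2 gives 3.7, and the step of a number 0.90 log units higher from compound 1 to compound 2 (beyond the scatter).

Compound 3 is `C#CCc1c(Cl)cc(N/C=N/O)cc1Cl`. In this assay compound 3 gives 2.8, which stands level with compound 1 at the digits recorded and, together with compound 1, at the bottom of the three numbers. The difference between the core of compound 3 and the core of compound 1 is not broken down here.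

Compound 4 is `C#CCc1c(Cl)cc(N/C=N/OC)cc1Cl`, not yet measured. It differs from compound 3 by methyl in place of hydrogen on an oxygen. This is the same kind of change as that from compound 1 to compound 2, but not the same one: there the oxygen sits on an aromatic ring with an aromatic carbon as its other neighbour, here the oxygen carries a double-bonded nitrogen as its other neighbour. Among the compounds with values here, the one measured instance of a methyl replacing hydrogen on an oxygen, a number 0.90 log units higher from compound 1 to compound 2 (beyond the scatter), is the only guide available, and it rests on a single pair.

Given that compound 3 gives 2.8, and that the step of a number 0.90 log units higher from compound 1 to compound 2 (beyond the scatter) was modest but beyond the scatter, a rise of similar or somewhat smaller size is expected from compound 3 to compound 4, namely a number 0.70 log units higher from compound 3 to compound 4 (beyond the scatter). Compound 4 is accordingly estimated at 3.5, with a plausible range from 3.1 to 3.9.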

Compound 4, partition coefficient: 3.3
Compound 4: middle estimate off by 0.20 log units, on the high side; the range from low to high includes it.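

In this assay methyl in place of hydrogen on an oxygen gives a number 0.50 log units higher from compound 3 to compound 4 (beyond the scatter) and, on the other core, a number 0.90 log units higher from compound 1 to compound 2 (beyond the scatter) and so raises the number in both pairs shown. The direction of the step therefore carries from one core to the other in this single instance, but no fixed size for the change follows from it: the two pairs differ both in the core and in the oxygen, which in compound 1 sits on an aromatic ring and in compound 3 has a double-bonded nitrogen as its other neighbour, and two pairs cannot separate those differences. Nothing measured here accounts for the size of either step.

The compounds shown leave open whether a third core would follow the same direction, and whether a longer chain such as propyl on the oxygen of compound 3 would extend the rise seen with methyl. As far as these compounds go, an amine or a carboxylic acid in place of the methoxy of compound 4 also remains open, and nothing here indicates where such a compound would stand relative to compound 3 or compound 4.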